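Replacing the oxazolylcarbonyl with acetyl on the piperidine nitrogen

The source may report more compounds than this note shows. Statements on the series, on what has been measured and on what is new or still open speak of the compounds shown alone.

Measured compounds, with their values in a physicochemical assay for lipophilicity, read by HPLC, measured as chromatographic lipophilicity, at pH 7.4; a lower number here means a more polar compound, a higher number a more lipophilic compound:
- compound 1, `O=C(C1CCN(c2ccncn2)CC1)N1N=CC[C@H]1c1ccccc1`: compound 1 gives 3.2
- compound 2, `O=C(c1cscn1)N1CCC(C(=O)N2N=CC[C@H]2c2ccccc2)CC1`: compound 2 gives 3
- compound 3, `O=C(c1cnco1)N1CCC(C(=O)N2N=CC[C@H]2c2ccccc2)CC1`: compound 3 gives 2.7

Compound 3 has the lowest of the three numbers in this assay. Its nearest neighbour is compound 2, with a number 0.30 log units lower from compound 2 to compound 3 (within the scatter); the gap to compound 1 is larger, with a number 0.50 log units lower from compound 1 to compound 3 (beyond the scatter). Between compound 1 and compound 2 the change was a number 0.20 log units lower from compound 1 to compound 2 (within the scatter).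

Compound 4, `CC(=O)N1CCC(C(=O)N2N=CC[C@H]2c2ccccc2)CC1`, has not been measured in this assay. It differs from compound 3 as follows: methyl in place of 1,3-oxazol-5-yl on a carbonyl carbon.

Among the compounds with values here, none of the measured steps removes an aromatic ring outright; each swaps one heteroaromatic group for another, and those swaps moved this assay by small amounts at most. They bear on the present step only loosely. Taking a methyl in place of a five-membered heteroaromatic ring as a change that most often lowers chromatographic lipophilicity modestly, the expected step is a number 0.30 log units lower from compound 3 to compound 4 (within the scatter), downward. Compound 4 is therefore estimated at 2.4, with a range from 2 to 2.8.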

Compound 4, distribution coefficient: 2.5
Estimate against measurement, compound 4: 0.10 log units below, within the range that was stated.
By their numbers in this assay, from the lowest: compounds 4, 3, 2 and 1 (each within the scatter of the next, the first and the last beyond it).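

Unlike the earlier steps, which swap one heteroaromatic group for another, methyl in place of 1,3-oxazol-5-yl on a carbonyl carbon leaves no ring on that carbonyl, and in this assay this gives a number 0.20 log units lower from compound 3 to compound 4 (within the scatter). Against the other two groups acetyl separates further, with a number 0.50 log units lower from compound 2 to compound 4 (beyond the scatter) for the 1,3-thiazol-4-yl group and a number 0.70 log units lower from compound 1 to compound 4 (beyond the scatter) for the pyrimidin-4-yl group. Taking away the ring therefore stays within the scatter of compound 3, yet compound 4 is the only compound shown that lies beyond the scatter of both compound 2 and compound 1.

Nothing shown accounts for the size of these steps. Still open, from the compounds shown here alone, is how a longer chain, an amine or a carboxylic acid in place of the methyl would read on the same carbonyl carbon.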